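A few compounds are considered here, and "the series" means these few. Any claim that something is new, unique, unknown or untested is made for them only; others in the source may bear on it.

Compound 3 `C=CC1=C(C(=O)NC2CCCCC2)C(c2ccc(OC)cc2)OC1` has been measured in a functional assay on A549 cells (Homo sapiens) for cytotoxicity, read by MTT assay, with a stated time of 24 h; a lower number here means a stronger inhibitor, a higher number a weaker inhibitor. For compound 3 the read-out is only a limit of the assay, > 100000 nM. Compound 2 `C=CC1=C(C(=O)Nc2ccc(OCC)cc2)C(c2ccc(OC)cc2)OC1` gives 17600 nM in this assay. For the measured compounds named here, the step of an at least 5.6-fold higher number from compound 2 to compound 3 (0.75 log units; beyond the scatter) is the one measured change on this amide nitrogen, and it runs toward weaker inhibition. Compound 1 `C=CC1=C(C(=O)NCC(C)C)C(c2ccc(F)cc2)OC1` likewise returns only a limit, > 100000 nM. Compound 4 `C=CC1=C(C(=O)NCC(C)C)C(c2ccc(OC)cc2)OC1` is not yet measured; it differs from compound 3 by isobutyl in place of cyclohexyl on an amide-type nitrogen. Compound 1 already carries this isobutyl amide. Because the limit of > 100000 nM in this assay, at which 2 of the 3 values shown sit, is where most of these values sit, no step beyond the scatter is expected from compound 3 to compound 4, a step that the limit leaves unreadable from compound 3 to compound 4. Compound 4 is therefore expected to give about 150000 nM in this assay, within 40000 nM to 600000 nM, most likely again reported as a limit.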

Compound 4, half-maximal inhibitory concentration: > 100000 nM
Compound 4 gave a limit, no number (the forecaster's own chance of this, stated with the estimate: 80%); the middle value lies beyond the limit too.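

In this assay the change to isobutyl on the amide-type nitrogen gives an at least 5.6-fold higher number from compound 2 to compound 4 (0.75 log units; beyond the scatter) and so repeats what cyclohexyl did, now with no ring in the entering group. Among the compounds shown, only the 4-ethoxyphenyl amide, compound 2, gives a measured number. The steps to compound 4 from compound 3 and from compound 1 cannot be read, as the values pile up at the assay limit: the limit of > 100000 nM in this assay, at which 3 of the 4 values shown sit.

From the compounds shown here alone, what a plain phenyl or a benzyl on that nitrogen would give stays open. So does whether the ethoxy group of compound 2 matters at all.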